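The source may hold more compounds than are shown below. What is called first, only, known or untested is meant among the compounds shown, and "the series" means these compounds.

Measured in a functional assay on HeLa cells (Homo sapiens) for antiproliferative activity, read by sulforhodamine B assay, with a stated time of 72 h; a lower number here means a stronger inhibitor, a higher number a weaker inhibitor:
- compound 1 `COc1ccccc1NC(=S)N/N=C/c1ccc2ccccc2n1`: > 100000 nM (a limit)
- compound 2 `NC(=S)N/N=C/c1ccc2cccnc2n1`: > 100000 nM (a limit)

Neither compound has a number, only a limit of the assay. Compound 1 stands at the limit of > 100000 nM in this assay, at which 2 of the 2 values shown sit, so there is no measured potency from which to count a change.

The next compound, compound 3 `S=C(N/N=C/c1ccc2ccccc2n1)Nc1cccc(Br)c1`, keeps the core of compound 1 and has 3-bromophenyl in place of 2-methoxyphenyl on an amide-type nitrogen. Among the measured compounds shown here, no measured pair shows what such a change does in this assay, so any expectation is a cautious one. A move towards stronger inhibition is expected, though another reading at the limit remains quite possible. The expected size is an at least 3.3-fold lower number from compound 1 to compound 3 (0.52 log units; beyond the scatter). Compound 3 is estimated at 30000 nM, with an expected range from 3000 nM to 100000 nM.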

Compound 3, half-maximal inhibitory concentration: 70000 nM
For compound 3 the middle estimate is 2.3-fold (0.37 log units) below the measured one; measured number inside the range.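

Among the compounds shown here, compound 3 gives the first actual number in this assay, 70000 nM, so 3-bromophenyl in place of 2-methoxyphenyl on an amide-type nitrogen yields a reading where the earlier compounds gave none. Compound 1 still has only a limit and no number: the limit of > 100000 nM in this assay, at which 2 of the 3 values shown sit. From the compounds shown here alone, the change can therefore be read only as a floor, an at least 1.4-fold lower number from compound 1 to compound 3 (0.15 log units; that floor lies within the scatter), which does not by itself establish a difference beyond the scatter, and its true size remains unknown.

This single pair leaves open whether 3-bromophenyl matters specifically or whether other groups in this place would read the same. Going by these compounds, how a plain phenyl, a longer alkyl chain or a carboxylic acid on that amide-type nitrogen would read in this assay also remains open.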